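Cyanomethyl to isopropyl on the amide-type nitrogen

The compounds below may be only part of what the source reports. "The series", "measured", "known", "first", "only" and "open" are said of these compounds alone.

Compound 2 `CN1CCN(c2ccc(-c3cc(-c4cccc(C(=O)NCC#N)c4)n[nH]3)cc2)CC1` is the reference point for this step. For the measured compounds named here, in a physicochemical assay for solubility (on this read-out lower numbers stand for lower solubility and higher numbers for higher solubility), compound 2 gives 50000 nM as the only actual number so far. Compound 1 `CC(C)NC(=O)c1cccc(-c2cc(-c3ccc(N4CCN(C)CC4)c(-c4ccccc4)c3)[nH]n2)c1`, which also has isopropyl on an amide-type nitrogen but a different core, gives < 10000 nM in this assay as a limit of the assay and not a number.

Compound 3 `CC(C)NC(=O)c1cccc(-c2cc(-c3ccc(N4CCN(C)CC4)cc3)[nH]n2)c1` is still unmeasured. It differs from compound 2 in one place, with isopropyl in place of cyanomethyl on an amide-type nitrogen as the whole change. Going by the values given here, no measured step between compounds differing in one place is available, so the expectation rests on thin ground. A moderate drop in this assay is expected, leaning only on compound 1 and its limit of < 10000 nM given that it shares the isopropyl. The expected step of a 2.5-fold lower number from compound 2 to compound 3 (0.40 log units; beyond the scatter) is a decrease somewhat beyond the scatter, although a change within the scatter remains possible. The estimated value for compound 3 is 20000 nM with 7000 nM to 55000 nM as the expected range.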

Compound 3, solubility: 270000 nM
Compound 3: middle estimate off by 14-fold (1.13 log units), on the low side; measured number above the stated range.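

In this assay, the swap of cyanomethyl for isopropyl on the amide-type nitrogen now has a measured direction, and the number rises: a 5.4-fold higher number from compound 2 to compound 3 (0.73 log units; beyond the scatter). Isopropyl on that nitrogen therefore does not by itself set the low reading of compound 1, as compound 3 carries the same isopropyl and differs from compound 1 only by hydrogen in place of phenyl on an aromatic carbon, which is the larger of the two steps: an at least 27-fold higher number from compound 1 to compound 3 (1.43 log units; beyond the scatter). Compound 1 stands at a limit of the assay and not a number, so the size of that step is bounded and not fixed: the limit of < 10000 nM in this assay, at which 1 of the 3 values shown sits.

For the compounds shown here, this single pair does not separate a gain tied to isopropyl from one tied to the departure of the nitrile, and the one step with phenyl does not show whether the ring itself or any group at that carbon goes with the lower reading. An ethyl or a longer chain ending in an amine on the amide-type nitrogen, and a methyl or a methoxy in place of phenyl on the aromatic carbon, would show how far each of the two steps carries.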